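Swapping a Sulfur-Bearing Side Chain for Isopropyl

This account rests on a few compounds, and the source may have more. Where it says the series, first, only, none or still open, it means among the compounds named here.

Of the compounds shown here, three with a shared core have been tested, each carrying a different side chain on the same saturated chain carbon. Compound 1 `CSCC[C@H](NC(=O)CN(c1nc(Cl)nc2[nH]cnc12)C1CC1)C(=O)OCc1ccccc1` is the starting point here. In a functional assay on the whole organism (Tail, strain ICR) with Mus musculus as the target, in the tail flick test, with a stated time of 120 min, at a dose of 25 umol/kg by the oral route (a higher number here means a stronger effect of the compound at the dose given, a lower number a weaker effect), compound 1 gives 31.6%. Compound 2 `O=C(OCc1ccccc1)[C@@H]1CCCN1C(=O)CN(c1nc(Cl)nc2[nH]cnc12)C1CC1` gives 38.4% in this assay, a number within the usual scatter of that of compound 1. Compound 3 `CC[C@H](C)[C@H](NC(=O)CN(c1ncnc2c1ncn2C1CCCCO1)C1CC1)C(=O)OCc1ccccc1` gives 20.4% in this assay. Among the three numbers compound 1 stands second highest: compound 2 is nearest, and compound 3 is furthest, lower by more than the scatter.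

Compound 4 `CC(C)[C@H](NC(=O)CN(c1nc(Cl)nc2[nH]cnc12)C1CC1)C(=O)OCc1ccccc1` differs from compound 1 in one place: isopropyl in place of 2-(methylsulfanyl)ethyl on a saturated chain carbon bound to an amide-type nitrogen and a carbonyl carbon. For the measured compounds named here, no measured pair shows this exact change, so nothing in the data points to a particular direction. The expected step of a number 1.6 percentage points lower from compound 1 to compound 4 (within the scatter) is therefore small, not beyond the usual scatter. For compound 4 the estimated activity in this assay is 30%, with a range from 16% to 44%.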

Compound 4, a percentage reported as activity, at one dose (the size of the read-out at that dose, not a potency): 27.3%
Beside the measured number, compound 4's estimate is 2.7 percentage points above it; the range from low to high includes it.
By their numbers in this assay, from the lowest: compounds 3, 4, 1 and 2 (each within the scatter of the next, the first and the last beyond it).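

In this assay, compound 1 and compound 4 form the first pair shown that differs in only one place, and the step is a number 4.3 percentage points lower from compound 1 to compound 4 (within the scatter). On this saturated chain carbon, isopropyl can therefore stand in place of 2-(methylsulfanyl)ethyl, giving up the sulfur and the hydrogen-bond acceptor counted for the leaving group, without a difference larger than the scatter at this single dose. No available evidence explains why the two numbers lie so close.

For the compounds shown here, one pair shows only that this particular swap makes no clear difference, so it gives no general rule for the position. As far as these compounds go, whether an amine, a carboxylic acid or a longer chain at the same carbon would move the number beyond the scatter remains open.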